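Benzyl in place of hexyl on a cytotoxicity urea series

This account rests on a few compounds, and the source may have more. Where it says the series, first, only, none or still open, it means among the compounds named here.

Of the compounds shown here, two sharing one core have been tested in a functional assay on WI-38 VA13 cells (Homo sapiens) for cytotoxicity; on this read-out lower numbers stand for an effect already at smaller amounts and higher numbers for an effect only at larger amounts of compound. Compound 1 `CCCCNC(=O)Nc1nc2ccc(NC(=O)c3c(Cl)cccc3Cl)cc2s1` carries a butyl chain on the urea and gives 0.028 ug/mL. Compound 2 `CCCCCCNC(=O)Nc1nc2ccc(NC(=O)c3c(Cl)cccc3Cl)cc2s1` carries a hexyl chain in its place; in this assay compound 2 gives 0.29 ug/mL, the higher of the two numbers. Among the compounds with values here, the step of a 10-fold higher number from compound 1 to compound 2 (1.02 log units; beyond the scatter) is the only measured step, and it shows that lengthening the saturated chain moves the number up strongly.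

As far as these compounds go, compound 3 `O=C(NCc1ccccc1)Nc1nc2ccc(NC(=O)c3c(Cl)cccc3Cl)cc2s1` is untested. The change from compound 2 is phenyl in place of pentyl on a saturated chain carbon bound to an amide-type nitrogen. Within the data shown here, no measured step involves a ring at this position, so the expectation rests on the chain series alone: the benzyl group carries fewer chain carbons than hexyl, so the number is expected to fall back somewhat toward compound 1, by a 2.9-fold lower number from compound 2 to compound 3 (0.46 log units; beyond the scatter), with wide uncertainty. Compound 3 is therefore estimated at 0.1 ug/mL in this assay, within a range of 0.02 ug/mL to 0.6 ug/mL.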

Compound 3, half-maximal effective concentration: 0.15 ug/mL
Estimate against measurement, compound 3: 1.5-fold (0.18 log units) below; the range from low to high includes it.
By their numbers in this assay, from the lowest: compound 1; then compounds 3 and 2 (each within the scatter of the next).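

In this assay a six-membered aromatic ring is tolerated on this saturated chain carbon in place of pentyl, and the step reads a 1.9-fold lower number from compound 2 to compound 3 (0.29 log units; within the scatter) so compound 3 cannot be told apart from compound 2. The benzyl group does not return the number to that of the butyl urea, as the step reads a 5.4-fold higher number from compound 1 to compound 3 (0.73 log units; beyond the scatter) and leaves compound 1 alone at the low end of the three. Nothing measured here accounts for phenyl and pentyl reading alike at this place.

As far as these compounds go, what remains open is how a cyclohexylmethyl or phenethyl group would read here, which would show whether the aromatic ring itself or the length of the group matters. Also open, from the compounds shown here alone, is where a pentyl chain would fall relative to compound 1 and compound 2 .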